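This account rests on a few compounds, and the source may have more. Where it says the series, first, only, none or still open, it means among the compounds named here.

Measured in a functional assay on SW-620 cells (Homo sapiens) for cytotoxicity, read by MTT assay, with a stated time of 72 h; a lower number here means a stronger inhibitor, a higher number a weaker inhibitor
compound 1 (`COc1ccc(/C=C2\CCC/C(=C\c3cccc(Cl)c3)C2=O)cc1OC`) 5100 nM
compound 2 (`COc1ccc(/C=C2\CCC/C(=C\c3cccc(Br)c3)C2=O)cc1OC`) 4200 nM
compound 3 (`COc1ccc(/C=C2\CCC/C(=C\c3ccc(O)cc3)C2=O)cc1OC`) 7700 nM

For the measured compounds named here, compound 3 stands within the scatter of the other two, as seen in a 1.5-fold higher number from compound 1 to compound 3 (0.18 log units; within the scatter) and in a 1.8-fold higher number from compound 2 to compound 3 (0.26 log units; within the scatter) on the numbers so far. Compound 4 (`COc1ccc(/C=C2\CCC/C(=C\c3ccc(O)c(Cl)c3)C2=O)cc1OC`) differs from compound 3 by chloro in place of hydrogen on an aromatic carbon in the change 4-hydroxyphenyl to 3-chloro-4-hydroxyphenyl. Going by the values given here, no measured step adds chloro to this group. Among the compounds with values here, the only halogen swap, a 1.2-fold lower number from compound 1 to compound 2 (0.08 log units; within the scatter) in this series, also stays within the scatter. A step beyond the scatter is therefore not expected in this assay at this point. The expected step is a 1.4-fold lower number from compound 3 to compound 4 (0.15 log units; within the scatter) and would lie within the scatter. The estimate for compound 4 is 5500 nM with an expected range from 2500 nM to 11000 nM for now.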

Compound 4, half-maximal inhibitory concentration: 7100 nM
Compound 4: the middle estimate sits 1.3-fold (0.11 log units) below what was measured, within the range that was stated.
By their numbers in this assay, from the lowest: compounds 2, 1, 4 and 3 (each within the scatter of the next).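

Chloro ortho to the hydroxy group makes no readable difference at this position in this assay (a 1.1-fold lower number from compound 3 to compound 4 (0.04 log units; within the scatter)). The 3-chloro-4-hydroxyphenyl group also stays level with the 3-bromophenyl group (a 1.7-fold higher number from compound 2 to compound 4 (0.23 log units; within the scatter)), and hydroxy on the 3-chlorophenyl ring does the same (a 1.4-fold higher number from compound 1 to compound 4 (0.14 log units; within the scatter)), so halogen and hydroxy together on this ring give no step beyond the scatter. Nothing available explains these steps. Going by these compounds, whether any group on this ring can move the number beyond the scatter remains open, for example an amine or a carboxylic acid in place of the hydroxy group.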